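The compounds below may be only part of what the source reports. "The series", "measured", "known", "first", "only" and "open" are said of these compounds alone.

Measured compounds:
- compound 1 `O=C(O)c1ccccc1-c1ccc(CCc2ncc(Cc3ccccc3F)[nH]2)cc1`: 177 nM
- compound 2 `CCCCc1cnc(C(CCCO)Cc2ccc(-c3ccccc3C(=O)O)cc2)[nH]1`: 1900 nM
- compound 3 `N#Cc1ccc(Cc2cnc(CCc3ccc(-c4ccccc4C(=O)O)cc3)[nH]2)cc1`: 5890 nM

All three share a core and were tested in an in vitro functional assay on cells for agonist activity at Bombesin receptor subtype-3 (Homo sapiens), read by luminescence and calcium flux; a lower number here means that less compound is needed, a higher number that more compound is needed for the effect. Among the three numbers, compound 2 stands second highest: compound 3 is its nearest neighbour, while compound 1 sits well apart at the low end. Among the measured compounds shown here, the only step between two compounds that differ in one place is the change from compound 1 to compound 3, a 33-fold higher number from compound 1 to compound 3 (1.52 log units; beyond the scatter), and it alters the aromatic group carried on the saturated chain carbon, not the chain itself.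

Compound 4 `CCCCc1cnc(C(CCC)Cc2ccc(-c3ccccc3C(=O)O)cc2)[nH]1` has not yet been measured. It differs from compound 2 in one place: hydrogen in place of hydroxy on a saturated chain carbon, four bonds along the chain from an aromatic carbon. For the measured compounds named here, no measured step touches this part of the molecule, so there is no direct guide to how the hydroxy contributes. Without such a guide, the expectation is that compound 4 will stay close to compound 2, with no step beyond the scatter in either direction, giving a 1.3-fold lower number from compound 2 to compound 4 (0.10 log units; within the scatter). On that basis compound 4 is estimated at 1500 nM in this assay, within a range from 500 nM to 4500 nM.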

Compound 4, half-maximal effective concentration: 1180 nM
For compound 4 the middle estimate is 1.3-fold (0.10 log units) above the measured one, and the stated range covers the measured number.
By their numbers in this assay, from the lowest: compound 1; then compounds 4 and 2 (each within the scatter of the next); then compound 3.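

In this assay the swap of hydrogen for hydroxy, which turns 3-hydroxypropyl into propyl, gives a 1.6-fold lower number from compound 2 to compound 4 (0.21 log units; within the scatter) and so stays within the usual scatter of repeated measurements. Among the compounds shown here, this is the first measured change at this position, on a saturated chain carbon four bonds along the chain from an aromatic carbon, and it shows that for this pair the number does not depend on the hydroxy, even though one hydrogen-bond donor and one hydrogen-bond acceptor leave with it; the aromatic group change in a 33-fold higher number from compound 1 to compound 3 (1.52 log units; beyond the scatter) is by contrast beyond the scatter, though it lies elsewhere in the molecule and says nothing about this position. No supporting data accompany this result that could say why the hydroxy makes so little difference here.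

Still open, as far as these compounds go, is whether this position accepts other groups as readily, for example an amine or a carboxylic acid in place of the hydroxy, or a chain longer than propyl. From the compounds shown here alone, it is also open whether the hydroxy would count for as little in a compound that differs from compound 2 elsewhere in the molecule.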